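Allyl to Cyano((tert-butyl)carbonyl)methyl on a Shared Core

This account rests on a few compounds, and the source may have more. Where it says the series, first, only, none or still open, it means among the compounds named here.

Compound 1 `C=CCOc1c(Br)cc(Br)cc1Oc1ccc(Br)cc1Br` gives 29 ug/mL.
Compound 2 `C#CCOc1c(Br)cc(Br)cc1Oc1ccc(Br)cc1Br` gives 29.5 ug/mL.
Compound 3 `BrCCCOc1c(Br)cc(Br)cc1Oc1ccc(Br)cc1Br` gives 30.3 ug/mL.

In a functional assay on U-937 cells (Homo sapiens) for cytotoxicity, read by MTT assay, with a stated time of 24 h (on this read-out higher numbers stand for weaker inhibition and lower numbers for stronger inhibition), the three measured compounds sit together. Compound 1 has the lowest of the three numbers, yet the steps of a 1.0-fold higher number from compound 1 to compound 2 (0.01 log units; within the scatter) and a 1.0-fold higher number from compound 1 to compound 3 (0.02 log units; within the scatter) are within the scatter, so no order among them can be read. Compound 4 `CC(C)(C)C(=O)C(C#N)Oc1c(Br)cc(Br)cc1Oc1ccc(Br)cc1Br` differs from compound 1 by cyano((tert-butyl)carbonyl)methyl in place of allyl on an oxygen on an aromatic ring. The measured steps exchange only small groups on a saturated chain carbon bound to an oxygen on an aromatic ring, and none of them moved the number; the new change is larger and untested. For compound 4 the expected step is therefore a 1.0-fold higher number from compound 1 to compound 4 (0.01 log units; within the scatter), with no direction beyond the scatter. Compound 4 is estimated at 30 ug/mL, within 15 ug/mL to 60 ug/mL.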

Compound 4, half-maximal inhibitory concentration: 32.5 ug/mL
The estimate for compound 4 lay 1.1-fold (0.03 log units) below the measured number; low and high end bracket the measured number.
By their numbers in this assay, from the lowest: compounds 1, 2, 3 and 4 (each within the scatter of the next).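

Putting cyano((tert-butyl)carbonyl)methyl on an oxygen on an aromatic ring gives a 1.1-fold higher number from compound 1 to compound 4 (0.05 log units; within the scatter), and the steps of a 1.1-fold higher number from compound 2 to compound 4 (0.04 log units; within the scatter) and a 1.1-fold higher number from compound 3 to compound 4 (0.03 log units; within the scatter) read the same way. Going by these compounds alone, this position, until now seen only with small groups, thus also takes a group with more heavy atoms and with hydrogen-bond acceptors, and the number stays within the scatter. Nothing available explains this flat response. On these data alone, whether an amine or a carboxylic acid on this oxygen would move the number remains open.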